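Two inactive chromene acetophenones and a shorter side chain

The compounds below may be only part of what the source reports. "The series", "measured", "known", "first", "only" and "open" are said of these compounds alone.

Measured compounds:
Compound 1 `CC(=O)c1ccc2c(c1O)[C@@H]1c3c(ccc4c(=O)c(C)c(C)oc34)OC[C@@H]1C(C)(C)O2` — in a functional assay on A549 cells (Homo sapiens) for cytotoxicity, read by MTT assay (on this read-out lower numbers stand for stronger inhibition and higher numbers for weaker inhibition), compound 1 gives > 100000 nM, a limit of the assay, not a number.
Compound 2 `CCC(=O)c1ccc2c(c1O)[C@H]1c3c(ccc4c(=O)c(C)coc34)OC[C@H]1C(C)(C)O2` — in this assay compound 2 gives > 100000 nM, again a limit rather than a number.

Compound 2 therefore stands nowhere in particular: both values shown are limits, and the limit of > 100000 nM in this assay, at which 2 of the 2 values shown sit, describes the whole picture. Among the measured compounds shown here, no step between measured compounds can be sized, and no pattern can be claimed from two limits.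

Compound 3 `CC(=O)c1ccc2c(c1O)[C@H]1c3c(ccc4c(=O)c(C)coc34)OC[C@H]1C(C)(C)O2` has not yet been tested in this assay. It differs from compound 2 by hydrogen in place of methyl on a saturated chain carbon bound to a carbonyl carbon, the same change as propanoyl to acetyl. With nothing but limits to go on, the expected step of a number no higher from compound 2 to compound 3 (the limit leaves the size open) is none beyond the scatter. Compound 3 is accordingly expected to give about 100000 nM, within 30000 nM to 300000 nM, most likely reported again as a limit.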

Compound 3, half-maximal inhibitory concentration: > 100000 nM
Compound 3: no number, only a limit; the forecaster's own chance of this, stated with the estimate: 85%; the middle value sits exactly at the limit.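

Compound 2 and compound 3 each give only a limit in this assay, not a number, and the change from propanoyl to acetyl therefore has no readable step. The compounds shown leave open whether any change to the shared core would give a measurable value, with every result so far at one limit: the limit of > 100000 nM in this assay, at which 3 of the 3 values shown sit.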